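This account rests on a few compounds, and the source may have more. Where it says the series, first, only, none or still open, it means among the compounds named here.

Measured so far:
- compound 1, `N#Cc1cccc(OC(=O)N2CCC(S(=O)(=O)C(c3ccccc3)c3ccccc3)CC2)c1`; in an assay on isolated protein for inhibition of Monoglyceride lipase (Rattus norvegicus), read by fluorescence, with stated times of 15 min and 3 h (on this read-out higher numbers stand for weaker inhibition and lower numbers for stronger inhibition), compound 1 gives 1000 nM
- compound 2, `N#Cc1cccc(OC(=O)N2CCC(OC(c3ccccc3)c3ccccc3)CC2)c1`; in this assay compound 2 gives 120 nM
- compound 3, `N#Cc1cc(O)cc(OC(=O)N2CCC(C(c3ccccc3)c3ccccc3)CC2)c1`; in this assay compound 3 gives 98.2 nM

Compound 3 has the lowest number of the three in this assay, but compound 2 sits within the scatter of it, so the two cannot be told apart. Only compound 1 stands clearly apart, with a higher number beyond the scatter.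

Compound 4, `N#Cc1ccnc(OC(=O)N2CCC(C(c3ccccc3)c3ccccc3)CC2)c1`, has not yet been measured. It differs from compound 3 in one place: 4-cyanopyridin-2-yl in place of 3-cyano-5-hydroxyphenyl on an oxygen next to a carbonyl group. The shared core, the carbamate and the diphenylmethyl piperidine are unchanged; the variation lies only in the aryl part of the carbamate. Within the data shown here, no measured pair isolates this change, so its size cannot be read from the data.

Given the carbamate is kept and the diphenylmethyl piperidine is kept, the expected step from compound 3 to compound 4 in this assay is a 1.6-fold higher number from compound 3 to compound 4 (0.21 log units; within the scatter), a small move towards a higher number, near the edge of the scatter. Compound 4 is therefore estimated at 160 nM, with a range from 40 nM to 650 nM.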

Compound 4, half-maximal inhibitory concentration: 20.1 nM
Compound 4: the middle estimate sits 8.0-fold (0.90 log units) above what was measured; the measured number lies below the stated range.
By their numbers in this assay, from the lowest: compound 4; then compounds 3 and 2 (each within the scatter of the next); then compound 1.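

The aryl part of the carbamate, on an oxygen next to a carbonyl group, is a position that moves the read-out: in this assay, 4-cyanopyridin-2-yl in place of 3-cyano-5-hydroxyphenyl gives a 4.9-fold lower number from compound 3 to compound 4 (0.69 log units; beyond the scatter) with the rest of the molecule unchanged. This single change also brings a hetero atom into the ring and removes the hydrogen-bond donor, so the step belongs to the exchange as a whole and not to either feature alone. Nothing available explains the drop in the number.

On these data alone, it remains open which of these two features carries the step, and whether the same exchange gives a similar step on the cores of compound 1 and compound 2. Also open, as far as these compounds go, is how this position responds when an amine or a carboxylic acid replaces the nitrile of the 4-cyanopyridin-2-yl group.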